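This account rests on a few compounds, and the source may have more. Where it says the series, first, only, none or still open, it means among the compounds named here.

Measured compounds in an ADME assay on L02 cells (Homo sapiens) for antiproliferative activity, read by MTT assay, with a stated time of 48 h; a lower number here means a stronger inhibitor, a higher number a weaker inhibitor:
Compound 1 `N#CC1=C(N)Oc2c(c3nc4ccccc4nc3c3ccccc23)C12C(=O)N(Cc1cnnn1-c1ccc(Cl)cc1)c1ccccc12` – compound 1 gives > 50000 nM, a limit of the assay rather than a number.
Compound 2 `N#CC1=C(N)Oc2c(c3nc4ccccc4nc3c3ccccc23)C12C(=O)N(Cc1cnnn1-c1ccc([N+](=O)[O-])cc1)c1ccccc12` – compound 2 gives > 50000 nM, again a limit.
Compound 3 `CC(=O)Nc1ccc(-n2nncc2CN2C(=O)C3(C(C#N)=C(N)Oc4c3c3nc5ccccc5nc3c3ccccc43)c3ccccc32)cc1` – compound 3 gives > 50000 nM, also a limit.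

All three share one core and differ only in the group on the phenyl ring attached to the triazole. Compound 3 stands at the limit of > 50000 nM in this assay, at which 3 of the 3 values shown sit; its value is a limit, so its true potency is not pinned down. The step from compound 2 to compound 3 is a step that the two limits leave unreadable from compound 2 to compound 3, the step from compound 1 to compound 3 is a step that the two limits leave unreadable from compound 1 to compound 3, and the step from compound 1 to compound 2 is a step that the two limits leave unreadable from compound 1 to compound 2. The new compound 4 `N#CC1=C(N)Oc2c(c3nc4ccccc4nc3c3ccccc23)C12C(=O)N(Cc1cnnn1-c1ccc(S(N)(=O)=O)cc1)c1ccccc12` differs from compound 3 by sulfamoyl in place of acetamido on an aromatic carbon. Among the measured compounds shown here, none of the measured steps can be read, because every value sits at the limit of > 50000 nM in this assay, at which 3 of the 3 values shown sit. No change beyond the scatter is expected in this assay. Compound 4 is therefore estimated at 50000 nM, between 20000 nM and 120000 nM. The estimated step is a number no higher from compound 3 to compound 4 (the limit leaves the size open).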

Compound 4, half-maximal inhibitory concentration: > 50000 nM
Compound 4: a limit, no number; the forecaster's own chance of this, stated with the estimate: 80%; the middle value lies on the limit itself.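

In this assay compound 4 gives > 50000 nM, a limit and not a number. Its steps from compound 1, compound 2 and compound 3 therefore cannot be read: the limit of > 50000 nM in this assay, at which 4 of the 4 values shown sit.

The compounds shown leave open how the true potencies of these four compounds compare, and whether any group on that phenyl ring changes them.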